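Naphthalene in place of the boron ring: compound 4

The source may report more compounds than this note shows. Statements on the series, on what has been measured and on what is new or still open speak of the compounds shown alone.

The measured compounds in an ADME assay (liver) for metabolic stability, with Liver microsome (Rattus norvegicus) as the target, using microsomes; on this read-out higher numbers stand for fast clearance and lower numbers for slow clearance:
compound 1, `CN(C(=O)c1ccc2ncsc2c1)c1ccc(OCB2C=Cc3ccccc3N2)cc1`, gives 73.3 mL/min/kg.
Compound 2, `CN(C(=O)c1csc(-c2cccnc2)n1)c1ccc(OCB2C=Cc3ccccc3N2)cc1`, reaches only the limit of the assay at > 283 mL/min/kg.
Compound 3, `CN(C(=O)c1cc(-c2ccccc2)n[nH]1)c1ccc(OCB2C=Cc3ccccc3N2)cc1`, gives 5.67 mL/min/kg.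

Among the numbers proper, compound 1 stands highest in this assay; its nearest neighbour is compound 3, reached by a 13-fold lower number from compound 1 to compound 3 (1.11 log units; beyond the scatter). The value of compound 2 is a limit and not a number (the limit of > 283 mL/min/kg in this assay, at which 1 of the 3 values shown sits). The steps that were measured, an at least 3.8-fold higher number from compound 1 to compound 2 (0.58 log units; beyond the scatter) and an at least 49-fold lower number from compound 2 to compound 3 (1.69 log units; beyond the scatter), all change the group on the carbonyl carbon.

Compound 4, `CN(C(=O)c1ccc2ncsc2c1)c1ccc(OCc2ccc3ccccc3c2)cc1`, differs from compound 1 elsewhere: a group of 10 heavy atoms (10 carbon; 2 six-membered aromatic rings of carbon only) in place of a group of 10 heavy atoms (8 carbon, 1 boron, 1 nitrogen; one six-membered non-aromatic ring with 2 hetero atoms, one six-membered aromatic ring of carbon only), on a saturated chain carbon bound to an oxygen on an aromatic ring. Among the measured compounds shown here, none of the measured steps touches this part of the molecule, so they give no direct guide to the size or direction of the change in this assay. With no comparison at hand, the step is expected to stay within the scatter; the estimate is a 1.1-fold higher number from compound 1 to compound 4 (0.04 log units; within the scatter). Compound 4 is therefore expected to give about 80 mL/min/kg in this assay, with a wide range from 30 mL/min/kg to 220 mL/min/kg to reflect the missing evidence.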

Compound 4, clearance: 48.3 mL/min/kg
The estimate for compound 4 lay 1.7-fold (0.22 log units) above the measured number, and the stated range covers the measured number.
By their numbers in this assay, from the lowest: compound 3; then compounds 4 and 1 (each within the scatter of the next). At a limit, above all of these: compound 2.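

In this assay, among the compounds shown here, this is the first step read on the saturated chain carbon bound to an oxygen on an aromatic ring, and exchanging the group of carbon, boron and nitrogen atoms for naphthalen-2-yl stays within the scatter: a 1.5-fold lower number from compound 1 to compound 4 (0.18 log units; within the scatter). With 1,3-benzothiazol-6-yl on the carbonyl carbon, the boron-containing group therefore shows no clear difference from an all-carbon group of the same heavy-atom count, even though this exchange also leaves out the hydrogen-bond donor and acceptor counted in the departing group. This small step contrasts with a change on the carbonyl carbon that lies beyond the scatter, a 13-fold lower number from compound 1 to compound 3 (1.11 log units; beyond the scatter), and nothing measured here offers an explanation for the small size of the exchange at the chain carbon.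

On these data alone, whether naphthalen-2-yl would read the same way alongside the 3-phenyl-1H-pyrazol-5-yl group of compound 3 or the 2-(pyridin-3-yl)-1,3-thiazol-4-yl group of compound 2 remains open. Also open, as far as these compounds go, is how a group of another kind at this place, such as a piperidine or a carboxylic acid, would compare with compound 1 and compound 4.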